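A Dichlorophenyl Arm Replaces a Fluorophenyl Arm

This account rests on a few compounds, and the source may have more. Where it says the series, first, only, none or still open, it means among the compounds named here.

Three compounds have been tested in a functional assay on HL-60 cells (Homo sapiens) for cytotoxicity, read by CCK-8 assay, with a stated time of 72 h; a higher number here means a weaker inhibitor, a lower number a stronger inhibitor:

compound 1 `COc1ccccc1/C=c1/[nH]c(=O)/c(=C\c2ccccc2OC)[nH]c1=O`: "not active" (no number reported)
compound 2 `C=CCn1c(=O)/c(=C\c2cccc(F)c2)[nH]c(=O)/c1=C\c1ccccc1OC`: 8890 nM
compound 3 `C=CCn1c(=O)/c(=C\c2cc(OC)c(OC)c(OC)c2)[nH]c(=O)/c1=C\c1cccc(Br)c1`: "not active" (no number reported)

For the measured compounds named here, compound 2 stands alone here: it is the only compound to return a numerical result in this assay, while compound 1 and compound 3 each gave no number at all. Its own value is weak, but it is the single reference available.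

Compound 4 `C=CCn1c(=O)/c(=C\c2ccc(Cl)c(Cl)c2)[nH]c(=O)/c1=C\c1ccccc1OC` has not yet been measured. It differs from compound 2 in one place: 3,4-dichlorophenyl in place of 3-fluorophenyl on a double-bonded chain carbon bound to an aromatic carbon.

Going by the values given here, no measured pair in this set differs by a single change, so no step size can be read off for a halogen exchange on this arm. Two of the three compounds tested gave no number, which makes a "not active" outcome for compound 4 a real possibility. If a number is obtained, compound 4 is expected to sit close to compound 2, with the step of a 1.4-fold lower number from compound 2 to compound 4 (0.14 log units; within the scatter) expected to be modest and within or just beyond the scatter. Compound 4 is therefore estimated at 6500 nM, within a range of 2000 nM to 25000 nM.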

Compound 4, half-maximal inhibitory concentration: "not active" (no number reported)
Compound 4: no number reported, and the estimate cannot be compared.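

For the compounds shown here, compound 4 reports no number, and compound 2 remains the only compound with one; no step between compound 2 and compound 4 can be read. Nothing measured here bears on this result. The compounds shown leave open how any single change on the shared core shifts the result in this assay.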